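The compounds below may be only part of what the source reports. "The series", "measured", "known", "first", "only" and "open" are said of these compounds alone.

Measured so far:
Compound 1, `Cn1c(=O)c2c(nc(SCCc3ccc(F)cc3)n2C)n(C)c1=O`: 71 nM
Compound 2, `Cn1c(=O)c2c(nc([S+]([O-])Cc3ccccc3)n2C)n(C)c1=O`: 131000 nM

In an assay on microsomes for inhibition of Amine oxidase [flavin-containing] B (Homo sapiens), read by fluorescence and spectrophotometry, with a stated time of 20 min (on this read-out lower numbers stand for stronger inhibition and higher numbers for weaker inhibition), compound 1 has the lowest of the two numbers; compound 2 sits far higher, and the two values together show a gap well beyond the usual scatter. Compound 3, `Cn1c(=O)c2c(nc(SCCCc3cccc(Cl)c3)n2C)n(C)c1=O`, has not yet been measured. It differs from compound 1 in one place: 3-chlorobenzyl in place of 4-fluorophenyl on a saturated chain carbon, two bonds along the chain from a sulfur. Going by the values given here, with no comparable pair measured, the change in the chain and in the halogen is expected to shift this assay only modestly, likely within or just beyond the scatter, in the direction of a somewhat higher number, as the step of a 1.5-fold higher number from compound 1 to compound 3 (0.19 log units; within the scatter) describes. Compound 3 is therefore expected to give about 110 nM, in a range from 30 nM to 450 nM.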

Compound 3, half-maximal inhibitory concentration: 62 nM
Estimate against measurement, compound 3: 1.8-fold (0.25 log units) above; the range from low to high includes it.
By their numbers in this assay, from the lowest: compounds 3 and 1 (each within the scatter of the next); then compound 2.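

In this assay the swap of 4-fluorophenyl for 3-chlorobenzyl on a saturated chain carbon, two bonds along the chain from a sulfur, gives a 1.1-fold lower number from compound 1 to compound 3 (0.06 log units; within the scatter) and so leaves the number unchanged within the usual scatter. This position therefore accepts a different halogen-bearing aromatic group with no measurable loss of inhibition. No supporting measurement explains why the two compounds match. The swap alters the halogen and the chain together, so neither can be judged alone. Going by these compounds, how an amine or a carboxylic acid would fare in place of the 3-chlorobenzyl also remains open.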